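Working notes: methyl in place of bromo on compound 3

The compounds below may be only part of what the source reports. "The series", "measured", "known", "first", "only" and "open" are said of these compounds alone.

- compound 1 `CC(C)Oc1ccc(Br)cc1C(C)NC(=O)N(C)S(=O)(=O)c1ccccc1`: 32100 nM
- compound 2 `CCOc1ccc(F)cc1C(C)NC(=O)NS(=O)(=O)c1ccc(Cl)cc1`: > 300000 nM, a limit
- compound 3 `CC(NC(=O)NS(=O)(=O)c1ccc(Cl)cc1)c1cc(Br)ccc1OCc1ccccc1`: 57500 nM

In a functional assay on thoracic aorta (Rattus norvegicus, strain Wistar), with a stated time of 15 min (on this read-out lower numbers stand for an effect already at smaller amounts and higher numbers for an effect only at larger amounts of compound), compound 3 gives 57500 nM, within the usual scatter of compound 1 at 32100 nM. Compound 2 reports only a limit, > 300000 nM. Compound 4 `Cc1ccc(OCc2ccccc2)c(C(C)NC(=O)NS(=O)(=O)c2ccc(Cl)cc2)c1` carries methyl in place of bromo on an aromatic carbon, para to a benzyloxy group (methyl in place of bromo on an aromatic carbon). Among the compounds with values here, no measured pair tests this change, so no step beyond the scatter is expected in this assay, and no direction is favoured. The expected 1.1-fold higher number from compound 3 to compound 4 (0.05 log units; within the scatter) is therefore small. Compound 4 is estimated at 65000 nM, with an expected range of 20000 nM to 200000 nM.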

Compound 4, half-maximal effective concentration: 65300 nM
Compound 4: the middle estimate sits 1.0-fold (0.00 log units) below what was measured; low and high end bracket the measured number.
By their numbers in this assay, from the lowest: compounds 1, 3 and 4 (each within the scatter of the next, the first and the last beyond it). At a limit, above all of these: compound 2.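

In this assay, methyl in place of bromo on an aromatic carbon, para to a benzyloxy group, gives a 1.1-fold higher number from compound 3 to compound 4 (0.06 log units; within the scatter). This pair is the only direct test of this position in the series, and the read-out does not separate the two groups there. Nothing in the data bears on the reason for this.

From the compounds shown here alone, whether an amine or a carboxylic acid at this position would move the number beyond the scatter remains open. Also open, going by these compounds, is whether the same change would read alike with an ethoxy group in place of the benzyloxy group.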